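Swapping an octyl chain for an aryl group on the core

The source may report more compounds than this note shows. Statements on the series, on what has been measured and on what is new or still open speak of the compounds shown alone.

Compound 1 `CCCCCCCCNc1nc(SCc2ccc(C(F)(F)F)cc2)nc2ccccc12` is tested in a functional assay on MGC-803 cells (Homo sapiens) for cytotoxicity, read by MTT assay, with a stated time of 72 h (a lower number here means a stronger inhibitor, a higher number a weaker inhibitor), where compound 1 gives 12600 nM, the lowest of the two plain numbers in this set. Compound 3 `FC(F)(F)c1ccc(CSc2nc(N3CCCCC3)c3ccccc3n2)cc1` gives 18600 nM in this assay, and the step of a 1.5-fold higher number from compound 1 to compound 3 (0.17 log units; within the scatter) is small. Compound 2 `CCCCCCCCCCCCNc1nc(SCc2ccc(C(F)(F)F)cc2)nc2ccccc12` reaches only a limit of this assay, > 50000 nM, so no exact number is known for it. Within the data shown here, the step of an at least 3.9-fold higher number from compound 1 to compound 2 (0.59 log units; beyond the scatter) is the one clear change among the measured pairs, and it matches (the limit of > 50000 nM in this assay, at which 1 of the 3 values shown sits). Compound 4 `FC(F)(F)c1ccc(CSc2nc(Nc3ccccc3C(F)(F)F)c3ccccc3n2)cc1` has not yet been measured in this assay. It differs from compound 1 in one place: 2-(trifluoromethyl)phenyl in place of octyl on a nitrogen on an aromatic ring. Among the measured compounds shown here, neither measured step replaces the chain with an aromatic ring, so no step bears directly on it; the step from compound 1 to compound 3, which also changes the group on that nitrogen, stayed within the scatter. Compound 4 is therefore expected to sit near compound 1, at an estimated 15000 nM (range 5000 nM to 45000 nM), a step of a 1.2-fold higher number from compound 1 to compound 4 (0.08 log units; within the scatter) that is expected to stay within the scatter.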

Compound 4, half-maximal inhibitory concentration: > 50000 nM
Compound 4 ended at the assay's limit (the forecaster's own chance of this, stated with the estimate: 20%); middle value at least 3.3-fold (0.52 log units) from the limit.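

Compound 4 is the only compound shown with an aromatic ring on this nitrogen, and putting 2-(trifluoromethyl)phenyl in place of octyl gives an at least 3.9-fold higher number from compound 1 to compound 4 (0.59 log units; beyond the scatter). The same group also does worse than the piperidine of compound 3, with an at least 2.6-fold higher number from compound 3 to compound 4 (0.42 log units; beyond the scatter), so this position does not accept every replacement of the octylamino group, as the step to compound 3 alone might have suggested. Both steps rest on a limit of the assay rather than on an exact number, a reading that compound 4 shares with the long-chain compound 2: the limit of > 50000 nM in this assay, at which 2 of the 4 values shown sit.

Going by these compounds, how far compound 4 lies past that limit stays unknown. On these data alone, whether a plain phenyl or a benzyl group on this nitrogen would return to the level of compound 1 is also open, so the effects of the ring and of its trifluoromethyl cannot yet be separated.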